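Shifting a Chlorine on the Benzyl Ether Group

The source may report more compounds than this note shows. Statements on the series, on what has been measured and on what is new or still open speak of the compounds shown alone.

Compound 1 `CC1(Cc2ccccc2)OS(=O)(=O)C=C1OCc1ccccc1`: 68000 nM
Compound 2 `CCC1(Cc2ccccc2)OS(=O)(=O)C=C1OCc1ccccc1Cl`: 38000 nM
Compound 3 `CCC1(Cc2ccccc2)OS(=O)(=O)C=C1OCCCCCCc1ccccc1`: < 200000 nM (a limit of the assay)

Three compounds sharing one core were tested in an ADME assay on HEL cells (Homo sapiens) for cytotoxicity, with a stated time of 3 days; a higher number here means that more compound is tolerated, a lower number that less compound is tolerated. Compound 2 gives 38000 nM, and compound 1 gives 68000 nM; the two are within the usual scatter of each other, so neither can be called the better tolerated. For compound 3 this assay gave only a limit, < 200000 nM, not a number. Compound 4 `CCC1(Cc2ccccc2)OS(=O)(=O)C=C1OCc1cccc(Cl)c1` has not been measured. It differs from compound 2 in one place: 3-chlorophenyl in place of 2-chlorophenyl on a saturated chain carbon bound to an oxygen on an unsaturated carbon. Since the atoms are the same and only their arrangement changes, the expected step from compound 2 to compound 4 in this assay is a 1.1-fold higher number from compound 2 to compound 4 (0.02 log units; within the scatter), no larger than the scatter. Compound 4 is therefore estimated at 40000 nM, ranging from 15000 nM to 110000 nM.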

Compound 4, half-maximal cytotoxic concentration: 50000 nM
Beside the measured number, compound 4's estimate is 1.3-fold (0.10 log units) below it; the measured number falls inside the stated range.
By their numbers in this assay, from the lowest: compounds 2, 4 and 1 (each within the scatter of the next).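

Going by these compounds alone, this is the first pair in the set that differs in one place only, so the chlorine's position can be read directly. In this assay, 3-chlorophenyl in place of 2-chlorophenyl gives a 1.3-fold higher number from compound 2 to compound 4 (0.12 log units; within the scatter) and so makes no measurable difference to how well the compound is tolerated. No measurement shown here bears on why this step is so small.

Still open, on these data alone, is whether a different group in place of the chlorine, such as an amine or a carboxylic acid, would move the number beyond the scatter.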